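Diyne-linked nucleoside series: aryl to cyclopropyl terminus

The compounds below may be only part of what the source reports. "The series", "measured", "known", "first", "only" and "open" are said of these compounds alone.

Compound 1 `CCCCCCc1ccc(C#CC#Cc2cn([C@H]3C[C@H](O)[C@@H](CO)O3)c(=O)[nH]c2=O)cc1` in an ADME assay on HEL cells (Homo sapiens) for cytotoxicity, read by microscopy (a lower number here means that less compound is tolerated, a higher number that more compound is tolerated), gives 100000 nM. Compound 2 `Nc1ccc(C#CC#Cc2cn([C@H]3C[C@H](O)[C@@H](CO)O3)c(=O)[nH]c2=O)cc1` reaches only the limit of this assay, > 100000 nM. The step of a number no lower from compound 1 to compound 2 (the limit leaves the size open) is therefore open in size, set by the limit of > 100000 nM in this assay, at which 1 of the 2 values shown sits. Compound 3 `O=c1[nH]c(=O)n([C@H]2C[C@H](O)[C@@H](CO)O2)cc1C#CC#CC1CC1` differs from compound 2 by cyclopropyl in place of 4-aminophenyl on a triple-bonded carbon. Within the data shown here, only that single step bears on the change, and it shows no lowering; no measured compound carries a group like cyclopropyl. The step of a number no higher from compound 2 to compound 3 (the limit leaves the size open) is expected to stay within the scatter. Compound 3 is estimated at 100000 nM, range 50000 nM to 200000 nM, with a fair chance that the reading is again only a limit.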

Compound 3, minimum cytotoxic concentration: > 100000 nM
Compound 3 ended at the assay's limit; the forecaster's own chance of this, stated with the estimate: 60%; the middle value lies on the limit itself.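

Compound 2 and compound 3 both end at a limit in this assay, so no step can be read between them: the limit of > 100000 nM in this assay, at which 2 of the 3 values shown sit. Going by these compounds, how far either compound lies past that limit, and whether cyclopropyl and 4-aminophenyl differ here at all, stays open.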